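The source may hold more compounds than are shown below. What is called first, only, known or untested is meant among the compounds shown, and "the series" means these compounds.

Working notes on the series.

Compound 1 `COc1ccc(OCCCOc2cc(=O)n(CCCO)c3c2CC(CC=C(C)C)C(C)(C)C3)cc1` and compound 2 `COc1ccc(OCCCOc2cc(=O)n(CCCO)c3c2CC(C/C=C(\C)CCC=C(C)C)C(C)(C)C3)cc1` share a core and differ only in the chain on the saturated ring carbon. In a functional assay on PANC-1 cells (Homo sapiens) for inhibition, read by MTT assay, with a stated time of 24 h, tested at 10 uM (a higher number here means more inhibition at the concentration tested (going by the name of the read-out), a lower number less inhibition), compound 1 gives 47.7%, and compound 2 gives 20%. Among the compounds with values here, the step of a number 27.7 percentage points lower from compound 1 to compound 2 (beyond the scatter) is the only measured step in the set, and on that basis compound 2 stands lowest of the two numbers in this assay, with compound 1 the nearer and higher neighbour.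

Compound 3 `CC(C)=CCC/C(C)=C/CC1Cc2c(OC(=O)Nc3ccc(F)c(Cl)c3)cc(=O)n(CCCO)c2CC1(C)C` is not yet measured. It keeps the longer chain of compound 2 and changes a different part of the molecule: (3-chloro-4-fluorophenyl)carbamoyl in place of 3-(4-methoxyphenoxy)propyl on an oxygen on an aromatic ring. Within the data shown here, no measured step touches this oxygen or either group exchanged there, so the step from compound 1 to compound 2, which concerns the chain only, does not bear on it. Without a comparable step the direction cannot be read from the data; the expectation is a modest rise a number 15 percentage points higher from compound 2 to compound 3 (beyond the scatter), with a range wide enough to admit no change or a fall. Compound 3 is therefore estimated at 35% in this assay, between 10% and 65%.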

Compound 3, a percentage reported as inhibition, at one concentration (the size of the read-out at that concentration, not a potency): 25%
Compound 3: the middle estimate sits 10 percentage points above what was measured, and the stated range covers the measured number.
By their numbers in this assay, from the lowest: compounds 2 and 3 (each within the scatter of the next); then compound 1.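

At the oxygen on an aromatic ring, (3-chloro-4-fluorophenyl)carbamoyl in place of 3-(4-methoxyphenoxy)propyl gives, in this assay, a number 5 percentage points higher from compound 2 to compound 3 (within the scatter), so the two groups cannot be told apart in this read-out while the longer chain of compound 2 is present. Within the data shown here, this is the first measured change at this oxygen: the earlier step concerned the chain alone, whereas this one shows that a change of linking atoms, halogens on the aromatic ring and hydrogen-bond donor and acceptor counts can leave the number within the scatter. No supporting data bear on why the two groups read alike.

The compounds shown leave open whether the same exchange at this oxygen would read alike with the shorter chain of compound 1, which differs from compound 3 in two places and so offers no direct comparison. They also leave open how a primary amine or a carboxylic acid at the end of a propyl chain on this oxygen would read in this assay, and how any of these groups would behave away from the single concentration tested.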